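The source may hold more compounds than are shown below. What is called first, only, known or untested is meant among the compounds shown, and "the series" means these compounds.

Measured so far in a functional assay on ileum (Cavia porcellus) for antagonist activity, with a stated time of 30 s; a higher number here means a weaker inhibitor, a lower number a stronger inhibitor:
- compound 1 `O=C(O)c1cc(=O)c2ccc(OCC(O)COc3ccccc3)cc2o1`: 7 ug/mL
- compound 2 `CC(=O)c1ccc(OCC(O)COc2ccc3c(=O)cc(C(=O)O)oc3c2)cc1O`: 28 ug/mL

Of these two, compound 2, at 28 ug/mL, has the higher number and is therefore the weaker inhibitor. The next molecule, compound 3 `C=CCc1c(OCC(O)COc2ccc3c(=O)cc(C(=O)O)oc3c2)ccc(C(C)=O)c1O`, keeps all of compound 2 but has allyl in place of hydrogen on an aromatic carbon, ortho to a hydroxy group, ortho to a large group and meta to an acetyl group (allyl in place of hydrogen on an aromatic carbon).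

Within the data shown here, only one measured step bears on this change. Swapping phenyl for 4-acetyl-3-hydroxyphenyl gave a 4.0-fold higher number from compound 1 to compound 2 (0.60 log units; beyond the scatter), so a change on this ring has already shifted this assay by a modest amount. Among the measured compounds shown here, no measured compound carries an allyl group, so the data do not fix the direction of the new step. A step of similar modest size is a reasonable guess, and a lower number is tentatively favoured. The expected change is a 2.8-fold lower number from compound 2 to compound 3 (0.45 log units; beyond the scatter). For compound 3 the estimated value is 10 ug/mL, with an expected range from 2 ug/mL to 40 ug/mL.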

Compound 3, half-maximal inhibitory concentration: 0.1 ug/mL
Estimate against measurement, compound 3: 100-fold (2.00 log units) above, and the stated range ends above it.
By their numbers in this assay, from the lowest: compound 3; then compound 1; then compound 2.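

In this assay the allyl group gives a 280-fold lower number from compound 2 to compound 3 (2.45 log units; beyond the scatter) and this step is far larger than the earlier change on the same ring, a 4.0-fold higher number from compound 1 to compound 2 (0.60 log units; beyond the scatter) and so the size of the earlier step gave little guide to this one. The aromatic carbon ortho to a hydroxy group, ortho to a large group and meta to an acetyl group is therefore a place where adding three carbons strongly changes the result, and the lower number means a much stronger inhibitor. Compound 3 stands at 0.1 ug/mL and has the lowest number of the three, so the 4-acetyl-3-hydroxyphenyl ring is not tied to weak inhibition once the allyl group is present.

The compounds shown leave open whether the double bond of the allyl group matters or any carbon chain would do here, a question that a propyl group, a methyl group or a longer chain at this carbon could answer, and whether an amine there would behave alike. No supporting measurement is available to explain the size of this step.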